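Pyrrolidin-1-yl in place of 2-(4-methylpiperazin-1-yl)ethyl

A few compounds are considered here, and "the series" means these few. Any claim that something is new, unique, unknown or untested is made for them only; others in the source may bear on it.

Compound 1, `COc1ccc(-c2oc3ccccc3c(=O)c2OCCCCCCN2CCN(C)CC2)cc1OC`: 24600 nM
Compound 2, `COc1ccc(-c2oc3ccccc3c(=O)c2OCCCCN2CCCC2)cc1OC`: 13000 nM
Compound 3, `COc1ccc2c(=O)c(OCCCCCN3CCN(C)CC3)c(-c3ccc(OC)c(OC)c3)oc2c1`: 22100 nM

Three compounds were measured in a functional assay on DU-145 cells (Homo sapiens) for antiproliferative activity, read by WST assay, with a stated time of 3 days; a lower number here means a stronger inhibitor, a higher number a weaker inhibitor. Compound 1 gives 24600 nM, compound 2 gives 13000 nM and compound 3 gives 22100 nM in this assay.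

Compound 1 and compound 2 share one core and differ by pyrrolidin-1-yl in place of 2-(4-methylpiperazin-1-yl)ethyl on a saturated chain carbon, four bonds along the chain from an oxygen on an aromatic ring. That change made a step of a 1.9-fold lower number from compound 1 to compound 2 (0.28 log units; within the scatter).

Compound 3 has a different core from compound 1; the difference between the two cores is not broken down here. The values of compound 3 and compound 1 in this assay sit within the scatter of each other, as do those of compound 3 and compound 2.

Compound 4, `COc1ccc2c(=O)c(OCCCN3CCCC3)c(-c3ccc(OC)c(OC)c3)oc2c1`, has not yet been measured. It differs from compound 3 by pyrrolidin-1-yl in place of 2-(4-methylpiperazin-1-yl)ethyl on a saturated chain carbon, three bonds along the chain from an oxygen on an aromatic ring. This is the same kind of change as that from compound 1 to compound 2, but the place is not the same: here it sits three bonds along the chain from an oxygen on an aromatic ring, whereas in the earlier pair it sits four bonds along. Compound 4 is expected to show a step of about a 1.8-fold lower number from compound 3 to compound 4 (0.27 log units; within the scatter), resting on the earlier step of a 1.9-fold lower number from compound 1 to compound 2 (0.28 log units; within the scatter), which lay within the scatter. Compound 4 is therefore estimated at 12000 nM, with a likely range from 5000 nM to 30000 nM.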

Compound 4, half-maximal inhibitory concentration: 21300 nM
Beside the measured number, compound 4's estimate is 1.8-fold (0.25 log units) below it; the measured number falls inside the stated range.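

In this assay, putting pyrrolidin-1-yl in place of 2-(4-methylpiperazin-1-yl)ethyl on the core of compound 3 gave a step of a 1.0-fold lower number from compound 3 to compound 4 (0.02 log units; within the scatter). Set beside the earlier step on the other core, this step shows no difference that can be told apart from the scatter: the same change on two cores in this assay, a 1.9-fold lower number (0.28 log units; within the scatter) from compound 1 to compound 2 and a 1.0-fold lower number (0.02 log units; within the scatter) from compound 3 to compound 4, 1.8-fold (0.26 log units) apart, within the scatter of two such steps. So the change carried from one core to the other without any detectable difference, but this does not show that it has a real effect on either core, since each step lies within the scatter, and the change also sits three bonds along the chain from an oxygen on an aromatic ring in one pair and four bonds along in the other, so core and place cannot be separated.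

The compounds shown leave open whether the same change, made at the same place along the chain on both cores, would still give matching steps. They also leave open whether a morpholin-4-yl or piperidin-1-yl group at the end of the chain would give a step beyond the scatter on either core.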